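Series notes on the shared core: propyl to butyl

The source may hold more compounds than are shown below. What is called first, only, known or untested is meant among the compounds shown, and "the series" means these compounds.

The three measured compounds share one core with a propyl on an amide-type nitrogen in a ring and differ only in the group on the oxygen. Compound 1 `CCCN1CCN(c2ccc(S(=O)(=O)Oc3cccc(C)c3)cc2)C1=O` gives 65000 nM in a functional assay on HT-29 cells (Homo sapiens) for antiproliferative activity, read by sulforhodamine B assay, with a stated time of 48 h; on this read-out higher numbers stand for weaker inhibition and lower numbers for stronger inhibition. Compound 2 `CCCN1CCN(c2ccc(S(=O)(=O)Oc3ccc(OC)c(OC)c3)cc2)C1=O` gives 14000 nM. Compound 3 `CCCN1CCN(c2ccc(S(=O)(=O)Oc3ccc(OC)cc3)cc2)C1=O` gives 16000 nM, the second highest of the three numbers; the step of a 1.1-fold higher number from compound 2 to compound 3 (0.06 log units; within the scatter) lies within the scatter, while the step of a 4.1-fold lower number from compound 1 to compound 3 (0.61 log units; beyond the scatter) lies beyond it. Compound 4 `CCCCN1CCN(c2ccc(S(=O)(=O)Oc3ccc(OC)cc3)cc2)C1=O` carries the change (methyl in place of hydrogen on a saturated chain carbon, three bonds along the chain from an amide-type nitrogen in a ring). Going by the values given here, neither measured step bears on this change: both concern the group on the oxygen, and no measured pair varies the chain on the amide-type nitrogen in a ring, so there is no precedent in these data for propyl to butyl. With nothing to go on beyond the unchanged group on the oxygen, no step beyond the scatter is expected, and the estimated step of no change at the digits printed from compound 3 to compound 4 (within the scatter) is centred on no change. Compound 4 is expected to give about 16000 nM, within a range from 6000 nM to 45000 nM.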

Compound 4, half-maximal inhibitory concentration: 35000 nM
Compound 4: the middle estimate sits 2.2-fold (0.34 log units) below what was measured; the range from low to high includes it.
By their numbers in this assay, from the lowest: compounds 2 and 3 (each within the scatter of the next); then compounds 4 and 1 (each within the scatter of the next).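

The chain on the amide-type nitrogen in a ring matters in this assay as well as the group on the oxygen: propyl to butyl gives a 2.2-fold higher number from compound 3 to compound 4 (0.34 log units; beyond the scatter) and so moves towards weaker inhibition. Going by these compounds alone, this single added methyl is the first measured change at this position, but only one pair supports it, and that pair carries the 4-methoxyphenyl group on the oxygen. Nothing available explains the step.

As far as these compounds go, it remains open whether a shorter chain such as ethyl or a longer chain such as pentyl would continue in the same direction, and whether a chain carrying an amine or a carboxylic acid would fit the trend. Also open, from the compounds shown here alone, is whether propyl to butyl gives a similar step with 3-methylphenyl on the oxygen.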